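Sec-butoxy for isobutyl on the carbonyl carbon

The source may hold more compounds than are shown below. What is called first, only, known or untested is meant among the compounds shown, and "the series" means these compounds.

The series shares one core; compound 1 `CC1=C(C(=O)CC(C)C)C(c2ccco2)NC(=O)N1`, compound 2 `CC1=C(C(=O)CC(C)C)C(c2ccoc2)NC(=O)N1` and compound 3 `CC1=C(C(=O)CC(C)C)C(c2ccsc2)NC(=O)N1` differ only in the group on the saturated ring carbon. In an assay on membranes from HeLa cells for displacement of a labelled ligand from adenosine receptor A3 (Homo sapiens), read by scintillation counting, with a stated time of 180 min, tested at 1 uM (a higher number here means more inhibition at the concentration tested (going by the name of the read-out), a lower number less inhibition), compound 1 gives 31%, compound 2 gives 18% and compound 3 gives 14%. The measured steps are a number 13 percentage points lower from compound 1 to compound 2 (beyond the scatter) and a number 17 percentage points lower from compound 1 to compound 3 (beyond the scatter), while a number 4 percentage points lower from compound 2 to compound 3 (within the scatter). Compound 3 thus holds the lowest of the three numbers, though its distance to compound 2 lies within the scatter and only its distance to compound 1 is beyond it.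

Compound 4 `CCC(C)OC(=O)C1=C(C)NC(=O)NC1c1ccsc1` keeps the thiophen-3-yl group of compound 3 and alters the other side of the core: sec-butoxy in place of isobutyl on a carbonyl carbon. Within the data shown here, none of the three measured steps touches the carbonyl carbon; every one of them varies the group on the saturated ring carbon, so no measured step bears on this change and its size cannot be read from the series. Without such a precedent the working expectation for compound 4 in this assay is a step of no change at the digits printed from compound 3 to compound 4 (within the scatter), not beyond the scatter in either direction. Compound 4 is accordingly estimated at 14%, with a range from 0% to 35%.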

Compound 4, a percentage reported as inhibition, at one concentration (the size of the read-out at that concentration, not a potency): 7%
Compound 4: middle estimate off by 7 percentage points, on the high side; the measured number falls inside the stated range.
By their numbers in this assay, from the lowest: compounds 4, 3 and 2 (each within the scatter of the next, the first and the last beyond it); then compound 1.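

Among these compounds, at the carbonyl carbon, the one position not touched by the earlier steps, this assay gives a number 7 percentage points lower from compound 3 to compound 4 (within the scatter) with thiophen-3-yl held fixed, so sec-butoxy and isobutyl are not told apart in this pair. The exchange adds an oxygen and a hydrogen-bond acceptor on the carbonyl carbon, and that difference in count does not produce a step beyond the scatter at the single concentration tested, so this position now has its first reading, which shows no resolved effect of this change. Nothing at hand explains this outcome or links it to any property of either group.

The compounds shown leave open whether sec-butoxy in place of isobutyl gives a step of similar size with furan-2-yl on the saturated ring carbon, where compound 1 stands at 31% and a loss would have more room to show. They also leave open how other groups on the carbonyl carbon would read in this assay, such as ethoxy, a longer chain such as hexyloxy, or an amine joined there as an amide.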